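The source may hold more compounds than are shown below. What is called first, only, known or untested is meant among the compounds shown, and "the series" means these compounds.

Measured in a functional assay on HCT-116 cells (Homo sapiens) for antiproliferative activity, read by MTT assay, with a stated time of 72 h; on this read-out lower numbers stand for stronger inhibition and higher numbers for weaker inhibition:
Compound 1 `O=C(CCc1cccc2c1B(O)OC2)Nc1ccc(I)cc1`: 50000 nM
Compound 2 `CC(C)(C)OC(=O)Nc1ccc(NC(=O)CCc2cccc3c2B(O)OC3)cc1`: 24000 nM
Compound 3 `O=C(CCc1cccc2c1B(O)OC2)Nc1ccc([N+](=O)[O-])cc1`: > 100000 nM, a limit of the assay

Compound 3 has no number of its own in this assay, only this limit. Its position is therefore known only from the steps that lead to it. One of them is an at least 4.1-fold higher number from compound 2 to compound 3 (0.61 log units; beyond the scatter). The other is an at least 2.0-fold higher number from compound 1 to compound 3 (0.30 log units; that floor lies within the scatter).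

Compound 4 `O=C(CCc1cccc2c1B(O)OC2)Nc1ccc(-c2ccccc2)cc1` has not yet been measured. It carries phenyl in place of nitro on an aromatic carbon. Among the compounds with values here, no measured compound holds phenyl at this place, so the expectation rests on what happens when other groups stand where nitro stands. Compound 1 reads 50000 nM with iodo there, and compound 2 reads 24000 nM with (tert-butoxycarbonyl)amino there. Between these two the exchange gave a 2.1-fold lower number from compound 1 to compound 2 (0.32 log units; beyond the scatter), so two quite different groups stay within a modest step of each other.

A modest to moderate move towards lower numbers is thus expected on leaving nitro, bringing compound 4 near compound 1 and compound 2. The expected step is an at least 3.3-fold lower number from compound 3 to compound 4 (0.52 log units; beyond the scatter). The estimate for compound 4 is 30000 nM, with an expected range from 8000 nM to 100000 nM.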

Compound 4, half-maximal inhibitory concentration: 13000 nM
Beside the measured number, compound 4's estimate is 2.3-fold (0.36 log units) above it; the measured number falls inside the stated range.
By their numbers in this assay, from the lowest: compounds 4 and 2 (each within the scatter of the next); then compound 1. At a limit, above all of these: compound 3.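

In this assay, a six-membered aromatic ring of carbon only is tolerated on this aromatic carbon, para to a large group: it gives a 3.8-fold lower number from compound 1 to compound 4 (0.59 log units; beyond the scatter), a modest gain over iodo, while a 1.8-fold lower number from compound 2 to compound 4 (0.27 log units; within the scatter) shows that phenyl and (tert-butoxycarbonyl)amino cannot be told apart here. The change from nitro to phenyl gives an at least 7.6-fold lower number from compound 3 to compound 4 (0.88 log units; beyond the scatter), so a group without hydrogen-bond acceptors can stand at this place with a clearly lower number than nitro, though this alone does not show what drives the difference. That step is only a floor, and its true size stays unknown, because compound 3 has only a limit of the assay: the limit of > 100000 nM in this assay, at which 1 of the 4 values shown sits.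

The compounds shown leave open whether an aromatic ring is needed at this place or whether other groups would serve as well, which a cyclohexyl ring, a free amine or a carboxylic acid there would help to settle. Also open, from the compounds shown here alone, is whether a longer chain leading to the amide would shift these numbers, all of which stay weak in this assay.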